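The source may report more compounds than this note shows. Statements on the series, on what has been measured and on what is new or still open speak of the compounds shown alone.

Compounds measured so far:
- compound 1 `O=C(NO)c1ccc(NCc2nc(-c3cccc4cnccc34)nn2-c2ccccc2)cc1`: 40.2%
- compound 2 `O=C(NO)c1ccc(NCc2nc(-c3cccnc3)nn2-c2ccccc2)cc1`: 57.7%
- compound 3 `O=C(NO)c1ccc(NCc2nc(-c3ccccc3Cl)nn2-c2ccccc2)cc1`: 75%

All three were tested in an assay on Sf9 cells for inhibition of protein deacetylase HDAC6 (Homo sapiens), read by fluorescence, with a stated time of 40 min, tested at 100 nM; a higher number here means more inhibition at the concentration tested (going by the name of the read-out), a lower number less inhibition. Compound 3 stands highest of the three, with compound 2 nearest a number 17.3 percentage points higher from compound 2 to compound 3 (beyond the scatter) and compound 1 furthest a number 34.8 percentage points higher from compound 1 to compound 3 (beyond the scatter); compound 1 to compound 2 is the remaining step of a number 17.5 percentage points higher from compound 1 to compound 2 (beyond the scatter).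

Compound 4 `O=C(NO)c1ccc(NCc2nc(-c3ccncc3)nn2-c2ccccc2)cc1` is the next compound to be measured in this assay. It differs from compound 3 in one place: pyridin-4-yl in place of 2-chlorophenyl on an aromatic carbon. Within the data shown here, the step that bears most directly on this change is the one from compound 2 to compound 3, where a 2-chlorophenyl group replaced a pyridin-3-yl group and gave a number 17.3 percentage points higher from compound 2 to compound 3 (beyond the scatter). Among the measured compounds shown here, compound 4 reverses that kind of change, putting a pyridyl group back in place of the 2-chlorophenyl, though with the ring nitrogen in a different position than in compound 2, for which no step is measured. A drop of modest size, beyond the scatter, is therefore expected, a number 19 percentage points lower from compound 3 to compound 4 (beyond the scatter). Compound 4 is estimated at 56%, within a range from 40% to 72%.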

Compound 4, a percentage reported as inhibition, at one concentration (the size of the read-out at that concentration, not a potency): 30.8%
Compound 4: middle estimate off by 25.2 percentage points, on the high side; the whole stated range lies above it.
By their numbers in this assay, from the lowest: compounds 4 and 1 (each within the scatter of the next); then compound 2; then compound 3.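

In this assay, among these compounds, this position on the shared core responds to where the ring nitrogen sits, not merely to whether a pyridyl group is present: pyridin-4-yl in place of pyridin-3-yl gives a number 26.9 percentage points lower from compound 2 to compound 4 (beyond the scatter), a contrast the earlier compounds could not show. The change from 2-chlorophenyl to pyridin-4-yl gives a number 44.2 percentage points lower from compound 3 to compound 4 (beyond the scatter), while the step to pyridin-4-yl from isoquinolin-5-yl, a number 9.4 percentage points lower from compound 1 to compound 4 (within the scatter), leaves those two groups within the scatter of each other. No measurement offered here accounts for these steps.

As far as these compounds go, it remains open whether the higher number of compound 3 depends on the chlorine or on the all-carbon ring. A plain phenyl group, a 2-methylphenyl group or a pyridin-2-yl group at this position would help separate these possibilities.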